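The compounds below may be only part of what the source reports. "The series", "measured", "known", "first", "only" and "open" are said of these compounds alone.

In a physicochemical assay for lipophilicity (on this read-out lower numbers stand for lower lipophilicity and higher numbers for higher lipophilicity), compound 1 (`CC(C)c1cc([N+](=O)[O-])cc(C(C)C)c1O`) gives 4.71 on the shared core. Compound 2 (`CC(C)c1cc(N(C)C)cc(C(C)C)c1O`) gives 4.52 and stands within the scatter of compound 1. Compound 3 (`CC(C)c1cc(N)cc(C(C)C)c1O`) carries amino in place of dimethylamino on an aromatic carbon, para to a hydroxy group and meta to two isopropyl groups (amino in place of dimethylamino on an aromatic carbon). Going by the values given here, one measured step bears on this change at the same aromatic carbon: dimethylamino in place of nitro gave a number 0.19 log units lower from compound 1 to compound 2 (within the scatter) in this assay for that pair. Among the compounds with values here, that step does not involve amino, and no measured pair isolates the removal of the carbon atoms of dimethylamino. The data therefore offer no direct size for this change. With compound 2 at 4.52 as the starting point and the structural change as the main guide, a step beyond the scatter towards lower numbers is expected. The estimated step is a number 0.82 log units lower from compound 2 to compound 3 (beyond the scatter) in this assay and remains an expectation. For compound 3 the estimated value is 3.7 with an expected range from 3.2 to 4.2 until a measurement is available.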

Compound 3, partition coefficient: 3.1
Compound 3: the middle estimate sits 0.60 log units above what was measured; the whole stated range lies above it.
By their numbers in this assay, from the lowest: compound 3; then compounds 2 and 1 (each within the scatter of the next).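

At this aromatic carbon, para to a hydroxy group, the read-out in this assay proves sensitive to the substituent: a number 0.19 log units lower from compound 1 to compound 2 (within the scatter) gave no separation, whereas amino in place of dimethylamino gives a number 1.42 log units lower from compound 2 to compound 3 (beyond the scatter) and amino in place of nitro gives a number 1.61 log units lower from compound 1 to compound 3 (beyond the scatter) on the shared core. Among the three compounds, only amino carries a hydrogen-bond donor at this position, and its entry alongside the loss of the two carbon atoms of dimethylamino marks the first change here that moves the number beyond the scatter. No measurement available here accounts for the size of this step.

The compounds shown leave open how much of the step follows the carbon atoms removed and how much follows the hydrogen-bond donor introduced, since both changes arrive together between compound 2 and compound 3. A methylamino group and an acetamido group on the same aromatic carbon would bear on that split, and would show whether the large step is particular to amino.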